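The source may hold more compounds than are shown below. What is called first, only, known or untested is meant among the compounds shown, and "the series" means these compounds.

Measured compounds:
- compound 1, `COc1cc2c(Oc3ccc(NC(=O)c4cc(-c5ccccc5C)ccn4)cc3F)ccnc2cc1OCCCN1CCCC1`; in a functional assay on HT-29 cells (Homo sapiens) for cytotoxicity, read by MTT assay, with a stated time of 72 h (on this read-out lower numbers stand for stronger inhibition and higher numbers for weaker inhibition), compound 1 gives 1150 nM
- compound 2, `COc1cc2c(Oc3ccc(NC(=O)c4cc(-c5ccccc5F)ccn4)cc3F)ccnc2cc1OCCCN1CCCC1`; compound 2 gives 230 nM
- compound 3, `COc1cc2c(Oc3ccc(NC(=O)c4nccc(-c5ccc(C)cc5)n4)cc3F)ccnc2cc1OCCCN1CCN(C)CC1`; compound 3 gives 210 nM

The change from compound 1 to compound 2 is fluoro in place of methyl on an aromatic carbon and it made a 5.0-fold lower number from compound 1 to compound 2 (0.70 log units; beyond the scatter). Compound 2 and compound 3 lie within the scatter of each other. The difference between the core of compound 1 and the core of compound 3 is not broken down here.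

Compound 4, `COc1cc2c(Oc3ccc(NC(=O)c4nccc(-c5ccc(F)cc5)n4)cc3F)ccnc2cc1OCCCN1CCN(C)CC1`, is not yet measured. It differs from compound 3 by fluoro in place of methyl on an aromatic carbon. This is the same kind of change as from compound 1 to compound 2, not the same: there the group sits ortho to a large group, here para to a large group. The step from compound 3 to compound 4 is expected to be a 1.4-fold lower number from compound 3 to compound 4 (0.15 log units; within the scatter), smaller than the earlier one, because compound 3 already gives 210 nM and the place differs. Compound 4 is estimated at 150 nM, expected between 60 nM and 450 nM.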

Compound 4, half-maximal inhibitory concentration: 42 nM
Compound 4: middle estimate off by 3.6-fold (0.55 log units), on the high side; the whole stated range lies above it.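

Fluoro in place of methyl, para to a large group, gives a 5.0-fold lower number from compound 3 to compound 4 (0.70 log units; beyond the scatter) in this assay and so matches the earlier step on a second core: the same change on two cores in this assay, a 5.0-fold lower number (0.70 log units; beyond the scatter) from compound 1 to compound 2 and a 5.0-fold lower number (0.70 log units; beyond the scatter) from compound 3 to compound 4, 1.0-fold (0.00 log units) apart, within the scatter of two such steps

The change therefore carries over between these two cores, even though the place of the group differs. Among these compounds, with only two pairs behind it, this does not show that the step holds on any other core or at any other place on the aromatic ring, and it does not show why fluoro gives the lower number.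

Still open, going by these compounds, is whether chloro or methoxy at the same place would track fluoro or methyl. Also open, on these data alone, is whether the step survives with a longer chain in place of the propyl linker to the terminal amine.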